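The source may hold more compounds than are shown below. What is called first, only, known or untested is meant among the compounds shown, and "the series" means these compounds.

Compound 1 `CC[C@@H](Nc1c(C#N)c(-c2ccc(-c3cccc(Cl)c3OC)cc2)nc2cnccc12)C(N)=O`: 3.1
Compound 2 `CCOc1ccccc1-c1ccc(-c2nc3cnccc3c(C[C@H](C)C(=O)O)c2C#N)cc1`: 2.2

Of the compounds shown here, two have been measured in a physicochemical assay for lipophilicity, read by HPLC, at pH 7.5; on this read-out lower numbers stand for lower lipophilicity and higher numbers for higher lipophilicity. Compound 1 gives 3.1, the higher of the two numbers, and compound 2 gives 2.2, a value that lies below it by more than the usual scatter. Compound 3 `CC[C@@H](Nc1c(C#N)c(-c2ccc(-c3ccccc3CO)cc2)nc2cnccc12)C(N)=O` has not yet been measured in this assay. It differs from compound 1 in one place: 2-(hydroxymethyl)phenyl in place of 3-chloro-2-methoxyphenyl on an aromatic carbon. With 2-(hydroxymethyl)phenyl entering in place of 3-chloro-2-methoxyphenyl, a downward step beyond the scatter is expected from compound 1 to compound 3, a number 1.20 log units lower from compound 1 to compound 3 (beyond the scatter). Compound 3 is therefore estimated at 1.9, within 1.4 to 2.4.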

Compound 3, distribution coefficient: 2.1
Beside the measured number, compound 3's estimate is 0.20 log units below it; the measured number falls inside the stated range.
By their numbers in this assay, from the lowest: compounds 3 and 2 (each within the scatter of the next); then compound 1.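

In this assay, 2-(hydroxymethyl)phenyl in place of 3-chloro-2-methoxyphenyl on an aromatic carbon, para to a large group, gives a number 1.00 log units lower from compound 1 to compound 3 (beyond the scatter) and so shows that the read-out responds to a change at this position. The change removes the chlorine and adds a hydrogen-bond donor, and one step cannot separate these differences. No measurement here explains the step. Going by these compounds, whether 2-methoxyphenyl without the chlorine would separate them stays open. So does where an aminomethyl or carboxylic acid group in place of the hydroxymethyl would fall.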